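Fluoro shift from compound 3 to compound 4

The source may hold more compounds than are shown below. What is called first, only, known or untested is meant among the compounds shown, and "the series" means these compounds.

Measured so far in an ADME assay on the whole organism (Mus musculus, strain CD-1) for pharmacokinetics, with a stated time of 6 h, at a dose of 10 mg/kg by the oral route; a higher number here means more compound in the circulation at the dose given, a lower number less compound in the circulation 
- compound 1 `Cc1c(C(=O)N2CC[C@H](N(C)C)C2)nc(-c2ccc(C#N)c(F)c2)n1-c1ccc2nn(C)cc2c1` gives 760 ng.h/mL 
- compound 2 `CN[C@H]1CCN(C(=O)c2nc(-c3ccc(C#N)c(F)c3)n(-c3cc4cn(C)nc4cc3F)c2C)C1` is recorded as "not determined" (no result reported) 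
- compound 3 `Cc1c(C(=O)N2CC[C@H](N(C)C)C2)nc(-c2ccc(C#N)c(F)c2)n1-c1cc2cn(C)nc2cc1F` gives 940 ng.h/mL 

The two available numbers lie within the scatter of each other, so compound 3 stands level with compound 1, and compound 2 offers no comparison. Compound 4 `Cc1c(C(=O)N2CC[C@H](N(C)C)C2)nc(-c2ccc(C#N)c(F)c2)n1-c1cc(F)c2nn(C)cc2c1` has the same atoms as compound 3, joined differently. The change is 7-fluoro-2-methyl-2H-indazol-5-yl in place of 6-fluoro-2-methyl-2H-indazol-5-yl on an aromatic nitrogen and amounts to 7-fluoro-2-methyl-2H-indazol-5-yl in place of 6-fluoro-2-methyl-2H-indazol-5-yl on an aromatic nitrogen. Within the data shown here, the only measured step that bears on this is a 1.2-fold higher number from compound 1 to compound 3 (0.09 log units; within the scatter) with fluoro in place of hydrogen on an aromatic carbon, and it lies within the scatter. Among the measured compounds shown here, no measured step relocates a fluoro, so the data indicate no direction. No step beyond the scatter is therefore expected in this assay for this change. The expected size is a 1.1-fold lower number from compound 3 to compound 4 (0.04 log units; within the scatter) and no more. The estimate for compound 4 is 850 ng.h/mL with an expected range from 400 ng.h/mL to 1800 ng.h/mL on repeat measurement.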

Compound 4, area under the concentration-time curve: 660 ng.h/mL
Beside the measured number, compound 4's estimate is 1.3-fold (0.11 log units) above it; the measured number falls inside the stated range.
By their numbers in this assay, from the lowest: compounds 4, 1 and 3 (each within the scatter of the next).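

Relocating the fluoro within the group on the aromatic nitrogen, with 7-fluoro-2-methyl-2H-indazol-5-yl in place of 6-fluoro-2-methyl-2H-indazol-5-yl, gives a 1.4-fold lower number from compound 3 to compound 4 (0.15 log units; within the scatter) in this assay, so this position tolerates the change without a step beyond the scatter. Against the group without fluoro, the new placement shows a 1.2-fold lower number from compound 1 to compound 4 (0.06 log units; within the scatter), and the earlier placement shows a 1.2-fold higher number from compound 1 to compound 3 (0.09 log units; within the scatter), so neither placement separates from compound 1. The numbers come with no measurement that would account for them.

Still open, going by these compounds, is whether a group other than fluoro on this aromatic ring, such as chloro or methoxy, would give a step beyond the scatter in this assay. Also open, on these data alone, is what a longer chain, such as ethyl or propyl, in place of the methyl on the 2-methyl-2H-indazol-5-yl group would do.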